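The source may report more compounds than this note shows. Statements on the series, on what has been measured and on what is new or still open speak of the compounds shown alone.

Compound 1 `CC(C)C[C@H](N)c1cc(C(F)(F)F)ccc1N1CCN(C(=O)CCNC2CCCCC2)CC1` gives 4800 nM in an assay on HEK293 cells for displacement of a labelled ligand from Melanocortin receptor 4 (Homo sapiens); on this read-out higher numbers stand for weaker inhibition and lower numbers for stronger inhibition. Compound 2 `CC(C)C[C@H](N)c1cc(C(F)(F)F)ccc1N1CCN(C(=O)C(C)Cc2ccc(Cl)cc2O)CC1` gives 36 nM in this assay. Compound 3 `CC(C)C[C@H](N)c1cc(C(F)(F)F)ccc1N1CCN(C(=O)COc2cccc(Cl)c2Cl)CC1` gives 2500 nM in this assay.

Compound 3 stands second highest of the three numbers; compound 1 lies nearest, and a 1.9-fold lower number from compound 1 to compound 3 (0.28 log units; within the scatter) is within the scatter, whereas a 69-fold higher number from compound 2 to compound 3 (1.84 log units; beyond the scatter) is large. Compound 4 `CC(C)C[C@H](N)c1cc(C(F)(F)F)ccc1N1CCN(C(=O)COc2ccc(O)cc2)CC1` differs from compound 3 in that (4-hydroxyphenyl in place of 2,3-dichlorophenyl on an oxygen on a saturated carbon). Among the measured compounds shown here, no measured step exchanges one aryl group for another on this oxygen; a 130-fold lower number from compound 1 to compound 2 (2.12 log units; beyond the scatter) and a 69-fold higher number from compound 2 to compound 3 (1.84 log units; beyond the scatter) replace the whole chain on the carbonyl carbon, and only compound 2, which carries a hydroxyl group, gives the low number. On this thin basis, for compound 4 the step of a 1.3-fold lower number from compound 3 to compound 4 (0.10 log units; within the scatter) is expected to stay modest. For compound 4 the estimated value is 2000 nM, within a range of 500 nM to 8000 nM.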

Compound 4, inhibition constant: 4600 nM
The estimate for compound 4 lay 2.3-fold (0.36 log units) below the measured number; the range from low to high includes it.
By their numbers in this assay, from the lowest: compound 2; then compounds 3, 4 and 1 (each within the scatter of the next).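

In this assay the exchange of 2,3-dichlorophenyl for 4-hydroxyphenyl on this oxygen gives a 1.8-fold higher number from compound 3 to compound 4 (0.26 log units; within the scatter) and the comparison with the cyclohexylamino chain gives a 1.0-fold lower number from compound 1 to compound 4 (0.02 log units; within the scatter) and both lie within the scatter. Compound 4 carries a hydroxyl group yet shows a 130-fold higher number from compound 2 to compound 4 (2.11 log units; beyond the scatter) and so a hydroxyl group alone does not go with the low number of compound 2. No supporting evidence bears on this result.

Open, from the compounds shown here alone, is whether an aminophenyl or a carboxyphenyl group on this oxygen would shift the number. Also open, going by these compounds, is whether a longer chain on the carbonyl carbon would do so.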